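Swapping a pyrimidine for a tetrahydroisoquinoline: stability outlook

The compounds below may be only part of what the source reports. "The series", "measured", "known", "first", "only" and "open" are said of these compounds alone.

Measured so far:
compound 1 `c1cnc(CN(CCCN2CCNCC2)[C@H]2CCCc3cccnc32)nc1`: 100%
compound 2 `CCN1CCN(CCCN(C[C@H]2Cc3ccccc3CN2)[C@H]2CCCc3cccnc32)CC1`: 59%
compound 3 `c1ccc2c(c1)CN[C@@H](CN(CCCCN1CCNCC1)[C@H]1CCCc3cccnc31)C2`: 82%

In an ADME assay on microsomes from liver (Homo sapiens) for metabolic stability, read by LC-MS, with a stated time of 10 min, tested at 0.5 uM (on this read-out higher numbers stand for a more stable compound and lower numbers for a less stable compound), compound 1 gives the highest of the three numbers; compound 3 sits nearest to it, and compound 2 is furthest. Compound 4 `c1ccc2c(c1)CN[C@@H](CN(CCCN1CCNCC1)[C@H]1CCCc3cccnc31)C2` is not yet measured. It differs from compound 1 by 1,2,3,4-tetrahydroisoquinolin-3-yl in place of pyrimidin-2-yl on a saturated chain carbon bound to an amine nitrogen. Within the data shown here, no measured step covers this exact exchange; the only step known, a number 23 percentage points higher from compound 2 to compound 3 (beyond the scatter), changes a different part of the molecule. The group that enters is already present in compound 3, whose value in this assay lies beneath that of compound 1, and in compound 2, which lies lower still. A modest downward step, a number 22 percentage points lower from compound 1 to compound 4 (beyond the scatter), is therefore expected. Compound 4 is estimated at 78%, in the range 58% to 95%.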

Compound 4, percent of the compound remaining: 100%
Estimate against measurement, compound 4: 22 percentage points below; the measured number lies above the stated range.
By their numbers in this assay, from the lowest: compound 2; then compound 3; then compounds 1 and 4 (each within the scatter of the next).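

In this assay, 1,2,3,4-tetrahydroisoquinolin-3-yl in place of pyrimidin-2-yl gives no change at the digits printed from compound 1 to compound 4 (within the scatter) here, so the entering group does not by itself lower the number at this position. Changes elsewhere still count with that group present: piperazin-1-yl in place of (piperazin-1-yl)methyl gives a number 18 percentage points higher from compound 3 to compound 4 (beyond the scatter) and hydrogen in place of ethyl on an amine nitrogen in a ring gives a number 41 percentage points higher from compound 2 to compound 4 (beyond the scatter) as well. From the compounds shown here alone, whether a carboxylic acid on the same saturated chain carbon would read alike remains open. Nothing available explains why these numbers fall as they do.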